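This account rests on a few compounds, and the source may have more. Where it says the series, first, only, none or still open, it means among the compounds named here.

Measured so far:
compound 1 `COc1ccc(CC2(C)CC(S(=O)(=O)c3ccc(F)cc3)=C(c3ccc(/C(N)=N/O)cc3)O2)cc1` sits at the limit of the test, > 100000 nM.
compound 2 `CC1(Cc2cccc(CO)c2)CC(S(=O)(=O)c2ccc(F)cc2)=C(c2ccc(/C(N)=N/O)cc2)O1` sits at the limit of the test, > 100000 nM.
compound 3 `CC1(/C=C/c2ccc(C(F)(F)F)cc2)CC(S(=O)(=O)c2ccc(F)cc2)=C(c2ccc(/C(N)=N/O)cc2)O1` gives 43900 nM.

Within the data shown here, in an ADME assay on cells (Peritoneal macrophage, Mus musculus, strain Balb/c) for cytotoxicity, read by resazurin assay, with a stated time of 72 h (on this read-out lower numbers stand for higher toxicity in this test and higher numbers for lower toxicity in this test), compound 3 therefore holds the only value that is an actual number; the other two compounds stop at a limit of the test. Compound 4 `CC1(Cc2ccccc2Br)CC(S(=O)(=O)c2ccc(F)cc2)=C(c2ccc(/C(N)=N/O)cc2)O1` differs from compound 3 by 2-bromobenzyl in place of 2-(4-(trifluoromethyl)phenyl)ethenyl on a saturated ring carbon. Among the measured compounds shown here, two measured steps bear on this change: an at least 2.2-fold lower number from compound 1 to compound 3 (0.35 log units; beyond the scatter) and an at least 2.2-fold lower number from compound 2 to compound 3 (0.35 log units; beyond the scatter). In both, a benzyl-type group left and the ethenyl-linked group entered, and both steps were beyond the scatter toward a lower number. The change to compound 4 runs the opposite way, a benzyl-type group coming back in place of the ethenyl-linked group, so a higher number is expected, of roughly the same size, a 2.3-fold higher number from compound 3 to compound 4 (0.36 log units; beyond the scatter). Given (the limit of > 100000 nM in this assay, at which 2 of the 3 values shown sit), the test may again report only a limit. Compound 4 is estimated at 100000 nM, with a range of 40000 nM to 300000 nM.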

Compound 4, half-maximal cytotoxic concentration: 109000 nM
For compound 4 the middle estimate is 1.1-fold (0.04 log units) below the measured one, and the stated range covers the measured number.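

In this assay, the change away from the ethenyl-linked group is now read as a step between two actual numbers on this saturated ring carbon: a 2.5-fold higher number from compound 3 to compound 4 (0.39 log units; beyond the scatter). Among these compounds, compound 4, carrying 2-bromobenzyl, gives 109000 nM, the first actual number for a benzyl-type group at this position, and all three benzyl-type compounds now lie on the higher side of compound 3, with none going against this. The steps from compound 1 and from compound 2 to compound 4 cannot be read, so the three benzyl-type groups cannot be ranked, due to this limit: the limit of > 100000 nM in this assay, at which 2 of the 4 values shown sit.

On these data alone, the change from compound 3 to compound 4 alters the linker and the aryl substituent together, so the contribution of each stays open. As far as these compounds go, how an amine or a carboxylic acid on the benzyl-type group, or a longer chain at this position, would read in this assay also remains open.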